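Replacing the furan ring of compound 1 with chlorophenyl

This account rests on a few compounds, and the source may have more. Where it says the series, first, only, none or still open, it means among the compounds named here.

Measured compounds:
compound 1 `N#C/C(=C\c1ccco1)C(=O)NCc1ccc(Cl)c(Cl)c1` — > 50000 nM
compound 2 `COc1ccc(CNC(=O)/C(C#N)=C/c2ccc(Cl)o2)cc1` — 9000 nM
compound 3 `COc1ccc(CNC(=O)/C(C#N)=C/c2ccc(C)cc2)cc1` — 33000 nM

In a functional assay on A2780 cells (Homo sapiens) for inhibition, read by MTT assay, with a stated time of 72 h (on this read-out higher numbers stand for weaker inhibition of growth and lower numbers for stronger inhibition of growth), compound 1 stands at a limit of the assay, > 50000 nM, so no number is known for it; it sits at the limit of > 50000 nM in this assay, at which 1 of the 3 values shown sits. In this assay compound 2 gives 9000 nM, and compound 3 gives 33000 nM. The unmeasured compound 4 `N#C/C(=C\c1ccc(Cl)cc1)C(=O)NCc1ccc(Cl)c(Cl)c1` differs from compound 1 by 4-chlorophenyl in place of furan-2-yl on a double-bonded chain carbon bound to a double-bonded chain carbon. Going by the values given here, the only measured step that bears on such a swap is a 3.7-fold higher number from compound 2 to compound 3 (0.56 log units; beyond the scatter), a modest rise in the number. The same direction is therefore expected here, with a step that the limit leaves unreadable from compound 1 to compound 4 as the expected step. Compound 4 is estimated at 90000 nM, with a range from 30000 nM to 300000 nM, and most probably reported again only as a limit.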

Compound 4, concentration for 50% growth inhibition: 32000 nM
For compound 4 the middle estimate is 2.8-fold (0.45 log units) above the measured one; the range from low to high includes it.
By their numbers in this assay, from the lowest: compound 2; then compounds 4 and 3 (each within the scatter of the next). At a limit, above all of these: compound 1.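

In this assay, 4-chlorophenyl in place of furan-2-yl gives an at least 1.5-fold lower number from compound 1 to compound 4 (0.19 log units; that floor lies within the scatter), so a six-membered ring on this carbon need not raise the number, as the 4-methylphenyl did in a 3.7-fold higher number from compound 2 to compound 3 (0.56 log units; beyond the scatter). On these data alone, the new compound gives a readable number, but the true size of the step stays unknown, because compound 1 holds only a limit: the limit of > 50000 nM in this assay, at which 1 of the 4 values shown sits.

The compounds shown leave open how much of this change comes from the ring and how much from its chlorine. They also do not tell what an amine or a carboxylic acid on that ring would do.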